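Stereochemistry in a bicyclic thiadiazole series: the mirror image

The source may report more compounds than this note shows. Statements on the series, on what has been measured and on what is new or still open speak of the compounds shown alone.

Measured so far in a functional assay on the whole organism for inhibition, with Mus musculus as the target; on this read-out higher numbers stand for an effect only at larger amounts of compound and lower numbers for an effect already at smaller amounts:
Compound 1 `CCCCSc1nsnc1[C@H]1CN2CCC[C@H]1C2` gives > 1 mg/kg, which is a limit of the assay and not a number.
Compound 2 `CCCCSc1nsnc1C1CN2CCC[C@H]1C2` gives 0.045 mg/kg.
Compound 3 `CCCCSc1nsnc1[C@@H]1CN2CCC[C@H]1C2` gives 0.026 mg/kg.

Compound 3 stands at the lowest of the two numbers shown; its nearest neighbour is compound 2, a step of a 1.7-fold lower number from compound 2 to compound 3 (0.24 log units; within the scatter), within the scatter. Compound 2 differs from compound 3 only in that one stereocentre at a saturated ring carbon is drawn without a configuration (the fact that one of compounds 2 and 3 is drawn with a defined configuration and the other without, at the place where they differ).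

Compound 4 `CCCCSc1nsnc1[C@H]1CN2CCC[C@@H]1C2` is the next step: the two compounds have the same atoms and bonds; at least one stereo element is drawn with a configuration in one of them and without one in the other: 2 of 3 stereo elements differ; a stereocentre at a saturated ring carbon is drawn S in compound 3 and R in compound 4; a stereocentre at a saturated ring carbon is drawn R in compound 3 and S in compound 4. Both drawn stereocentres are inverted, so compound 4 is the mirror image of compound 3.

The measured steps that bear on this are an at least 38-fold lower number from compound 1 to compound 3 (1.58 log units; beyond the scatter) and an at least 22-fold lower number from compound 1 to compound 2 (1.34 log units; beyond the scatter), each large and beyond the scatter, and each turning on a single drawn stereocentre the fact that one of compounds 1 and 3 is drawn with a defined configuration and the other without, at the place where they differ (the fact that one of compounds 1 and 2 is drawn with a defined configuration and the other without, at the place where they differ). Inversion at one centre already costs much; inversion at both is untested here. A rise in this assay from compound 3 to compound 4 is therefore expected, of about a 19-fold higher number from compound 3 to compound 4 (1.28 log units; beyond the scatter), with a real chance of a limit only. Compound 4 is estimated at 0.5 mg/kg, range 0.05 mg/kg to 5 mg/kg.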

Compound 4, dose for half-maximal effect: 0.012 mg/kg
Estimate against measurement, compound 4: 42-fold (1.62 log units) above; the measured number lies below the stated range.
By their numbers in this assay, from the lowest: compound 4; then compounds 3 and 2 (each within the scatter of the next). At a limit, above all of these: compound 1.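

Inverting both drawn stereocentres costs nothing in this assay; the mirror image is in fact modestly better, with a 2.2-fold lower number from compound 3 to compound 4 (0.34 log units; beyond the scatter), and compound 2, with one centre undrawn, also gives way to it, with a 3.8-fold lower number from compound 2 to compound 4 (0.57 log units; beyond the scatter). Compound 1 gives > 1 mg/kg, which is a limit of the assay and not a number. Since an at least 83-fold lower number from compound 1 to compound 4 (1.92 log units; beyond the scatter) turns on a single centre, just as the step to compound 3 does, the large loss follows the relative arrangement of the two centres, which compound 3 and compound 4 share, and not the sense of either centre alone: the fact that one of compounds 1 and 4 is drawn with a defined configuration and the other without, at the place where they differ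

Open, as far as these compounds go, is whether the mirror image of compound 1 also stays at the limit. Also open, from the compounds shown here alone, is whether the modest preference for compound 4 over compound 3 survives replacing the butylthio chain with a longer chain such as hexylthio.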